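A few compounds are considered here, and "the series" means these few. Any claim that something is new, unique, unknown or untested is made for them only; others in the source may bear on it.

Values in an ADME assay on MRC5 cells (Homo sapiens) for antiproliferative activity, read by fluorescence and resazurin assay, with a stated time of 68 h; on this read-out lower numbers stand for an effect already at smaller amounts and higher numbers for an effect only at larger amounts of compound:
- Compound 1 `Cc1ccc(-c2cc(C(=O)Nc3cccnc3)c3cc(Cl)ccc3n2)cc1`: 21000 nM
- Compound 2 `Cc1cc(Nc2cc(C(=O)NCCN3CCCC3)c3cc(F)ccc3n2)on1`: > 50000 nM (a limit of the assay, not a number)
- Compound 3 `CN1CCN(c2cc(C(=O)NCCN3CCCC3)c3cc(F)ccc3n2)CC1`: 20000 nM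

Compound 3 gives 20000 nM, within the scatter of compound 1 at 21000 nM. Compound 4 `O=C(NCCN1CCCC1)c1cc(NCCN2CCCCC2)nc2ccc(F)cc12` has not yet been measured. It carries (2-(piperidin-1-yl)ethyl)amino in place of 4-methylpiperazin-1-yl, on the aromatic carbon next to the ring nitrogen ((2-(piperidin-1-yl)ethyl)amino in place of 4-methylpiperazin-1-yl on an aromatic carbon). Among the measured compounds shown here, one measured step bears on this place: an at least 2.5-fold lower number from compound 2 to compound 3 (0.39 log units; beyond the scatter). It involves a different amino group and ends on a limit, so it is only a loose guide. No step beyond the scatter is therefore expected in this assay, in either direction. The expected change is a 1.3-fold lower number from compound 3 to compound 4 (0.12 log units; within the scatter). For compound 4 the estimated value is 15000 nM, with an expected range from 4000 nM to 50000 nM.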

Compound 4, half-maximal effective concentration: 19000 nM
For compound 4 the middle estimate is 1.3-fold (0.10 log units) below the measured one; measured number inside the range.
By their numbers in this assay, from the lowest: compounds 4, 3 and 1 (each within the scatter of the next). At a limit, above all of these: compound 2.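

In this assay, (2-(piperidin-1-yl)ethyl)amino and 4-methylpiperazin-1-yl on the aromatic carbon next to the ring nitrogen cannot be told apart (a 1.1-fold lower number from compound 3 to compound 4 (0.02 log units; within the scatter)). Compound 4 keeps the amino nitrogen of compound 2, so the earlier separation from compound 2 does not require the piperazine ring on that carbon (an at least 2.6-fold lower number from compound 2 to compound 4 (0.42 log units; beyond the scatter)). The value of compound 2 is a limit of the assay, not a number: the limit of > 50000 nM in this assay, at which 1 of the 4 values shown sits.

The compounds shown leave open whether a morpholine or a plain primary amine on this carbon would move the number beyond the scatter.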